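Capping the chain amine: sulfamide to urea

The source may hold more compounds than are shown below. What is called first, only, known or untested is meant among the compounds shown, and "the series" means these compounds.

Three measured compounds share one core with a sulfone-linked phenyl ring and a short chain carrying a nitrogen. Compound 1 `CNCC1CCCc2cc(S(=O)(=O)c3ccccc3)ccc21` gives 0.316 nM in an assay on isolated protein for displacement of a labelled ligand from 5-hydroxytryptamine receptor 6 (Homo sapiens); on this read-out lower numbers stand for stronger inhibition and higher numbers for weaker inhibition. Compound 2 `NC[C@@H]1CCCc2cc(S(=O)(=O)c3cccc(O)c3)ccc21` gives 0.251 nM in this assay. Compound 3 `CN(C[C@@H]1CCCc2cc(S(=O)(=O)c3cccc(F)c3)ccc21)S(N)(=O)=O`, which carries methyl(sulfamoyl)amino on the chain, gives 3.98 nM in this assay; this is the highest of the three numbers, beyond the scatter from both compound 1 and compound 2, so the chain nitrogen capped in this way sits weaker than the two free amines here. Within the data shown here, no single-point pair exists among the measured compounds, so no measured step is available.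

Compound 4 `CNC(=O)NC[C@@H]1CCCc2cc(S(=O)(=O)c3cccc(F)c3)ccc21` is not yet measured. The change from compound 3 is (methylcarbamoyl)amino in place of methyl(sulfamoyl)amino on a saturated chain carbon bound to a saturated ring carbon. Both groups cap the chain nitrogen with a methyl-bearing substituent, so the step in this assay is expected to be small, within or near the scatter, with no clear direction; the expected step is a 1.3-fold higher number from compound 3 to compound 4 (0.10 log units; within the scatter). Compound 4 is thus estimated at 5 nM in this assay, with a range from 1.5 nM to 16 nM.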

Compound 4, inhibition constant: 0.398 nM
The estimate for compound 4 lay 13-fold (1.10 log units) above the measured number; measured number outside the range, below it.
By their numbers in this assay, from the lowest: compounds 2, 1 and 4 (each within the scatter of the next); then compound 3.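

In this assay, a 10-fold lower number from compound 3 to compound 4 (1.00 log units; beyond the scatter) shows that on a saturated chain carbon bound to a saturated ring carbon, (methylcarbamoyl)amino and methyl(sulfamoyl)amino are not interchangeable. The weaker number of compound 3 therefore cannot be read as a general result of substituting the chain nitrogen, since compound 4 also carries a substituent on that nitrogen and gives 0.398 nM in this assay. No measurement shown here accounts for this difference between the two capping groups.

Among the compounds shown, no free amine carries the same fluorophenyl sulfone, so the effect of either cap relative to an uncapped nitrogen cannot be read directly. Going by these compounds, it also remains open whether an acetamide or a methyl carbamate on the chain nitrogen would track the urea or the sulfamide.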